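Methyl Moved Around the Aryl Ring of a Pyran Core

The compounds below may be only part of what the source reports. "The series", "measured", "known", "first", "only" and "open" are said of these compounds alone.

Compound 2 `Cc1ccccc1C1C(C#N)=C(N)OC(c2c[nH]c3ccccc23)=C1C#N` gives 10.4% in a functional assay, tested at 50 ug/mL; on this read-out higher numbers stand for a stronger effect at the one concentration tested and lower numbers for a weaker effect. Among the compounds with values here, its only companion is compound 1 `COc1ccc(C2C(C#N)=C(N)OC(c3c[nH]c4ccccc34)=C2C#N)cc1OC`, which in this assay gives 14.5%; the two stand together at the bottom of the scale, separated by a number 4.1 percentage points lower from compound 1 to compound 2 (within the scatter), a gap within the scatter. Compound 3 `Cc1ccc(C2C(C#N)=C(N)OC(c3c[nH]c4ccccc34)=C2C#N)cc1` differs from compound 2 in a single place: 4-methylphenyl in place of 2-methylphenyl on a saturated ring carbon. Within the data shown here, the one measured step swapped an entire aryl group and still stayed within the scatter, while no measured pair tests a methyl moved from one spot on the ring to another. With both measured numbers low and close, no step beyond the scatter is expected for compound 3. Compound 3 is therefore estimated at 12% in this assay, with a range from 3% to 22%, which means an expected step of a number 1.6 percentage points higher from compound 2 to compound 3 (within the scatter), within the scatter.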

Compound 3, a percentage reported as activity, at one concentration (the size of the read-out at that concentration, not a potency): 5.2%
Beside the measured number, compound 3's estimate is 6.8 percentage points above it; measured number inside the range.
By their numbers in this assay, from the lowest: compounds 3, 2 and 1 (each within the scatter of the next).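

Moving the methyl around the aryl ring on the saturated ring carbon now has a measured pair, and in this assay it gives a number 5.2 percentage points lower from compound 2 to compound 3 (within the scatter), so the place of the methyl on this ring cannot be told apart from the scatter. Replacing 3,4-dimethoxyphenyl with 4-methylphenyl on the same carbon gives a number 9.3 percentage points lower from compound 1 to compound 3 (within the scatter), a second swap of a whole aryl group at this position that stays within the scatter, and all three aryl groups thus sit together on this read-out. Nothing measured here bears on why the numbers fall as they do.

Going by these compounds, whether an aryl group carrying an amine or a carboxylic acid, or a longer chain in place of the methyl, would move the number beyond the scatter stays open. Also open, on these data alone, is whether any change to the 1H-indol-3-yl group would do so.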